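Swapping the isopentyloxy chain end for an ethoxy group

The compounds below may be only part of what the source reports. "The series", "measured", "known", "first", "only" and "open" are said of these compounds alone.

In an assay on cells for antagonist activity at transient receptor potential cation channel subfamily V member 1 (Homo sapiens), read by FLIPR and calcium flux, with a stated time of 6 min (a lower number here means a stronger inhibitor, a higher number a weaker inhibitor), compound 3 `CC(C)CCOc1nc(C(C)(C)C)ccc1CNC(=O)C(C)c1ccc(NS(C)(=O)=O)c(F)c1` gives 0.8 nM, the lowest of the three numbers in hand. Compound 1 `CC(C(=O)NCc1ccc(C(C)(C)C)nc1N1CCCCCC1)c1ccc(NS(C)(=O)=O)c(F)c1` gives 0.9 nM and compound 2 `CCCCCCOc1nc(C(C)(C)C)ccc1CNC(=O)C(C)c1ccc(NS(C)(=O)=O)c(F)c1` gives 2.7 nM; the gap a 1.1-fold lower number from compound 1 to compound 3 (0.05 log units; within the scatter) lies within the scatter, while a 3.4-fold lower number from compound 2 to compound 3 (0.53 log units; beyond the scatter) and a 3.0-fold higher number from compound 1 to compound 2 (0.48 log units; beyond the scatter) are modest but real. Compound 4 `CCOCCOc1nc(C(C)(C)C)ccc1CNC(=O)C(C)c1ccc(NS(C)(=O)=O)c(F)c1` differs from compound 3 by ethoxy in place of isopropyl on a saturated chain carbon, two bonds along the chain from an oxygen on an aromatic ring. For the measured compounds named here, only the step from compound 2 to compound 3 touches this chain end, and no measured compound carries an added acceptor there, so a modest change at most is expected, if anything toward a higher number. Compound 4 is therefore expected to give 2 nM, between 0.7 nM and 6 nM, a step of a 2.5-fold higher number from compound 3 to compound 4 (0.40 log units; beyond the scatter).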

Compound 4, inhibition constant: 23.9 nM
Estimate against measurement, compound 4: 12-fold (1.08 log units) below; the measured number lies above the stated range.
By their numbers in this assay, from the lowest: compounds 3 and 1 (each within the scatter of the next); then compound 2; then compound 4.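

In this assay ethoxy in place of isopropyl on this saturated chain carbon gives a 30-fold higher number from compound 3 to compound 4 (1.48 log units; beyond the scatter) and ethoxy in place of butyl gives an 8.9-fold higher number from compound 2 to compound 4 (0.95 log units; beyond the scatter) and this chain end, which moved the number only modestly while it held carbon alone, moves it much further once it holds an oxygen. In place of azepan-1-yl on the aromatic carbon, 2-ethoxyethoxy gives a 27-fold higher number from compound 1 to compound 4 (1.42 log units; beyond the scatter) while isopentyloxy there gives a 1.1-fold lower number from compound 1 to compound 3 (0.05 log units; within the scatter) which stays within the scatter. Nothing measured here accounts for this rise.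

The compounds shown leave open whether the higher number follows the oxygen itself or its place in the chain, and how a 3-ethoxypropoxy chain, a terminal hydroxyl or an amine would read here.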